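Thiophene-to-phenyl swap beside the ring nitrogen

The source may report more compounds than this note shows. Statements on the series, on what has been measured and on what is new or still open speak of the compounds shown alone.

Compound 1 `Oc1cccc(-c2cc(-c3ccc(Cl)cc3)nc(-c3cccs3)c2)c1` gives 10500 nM in a functional assay on T47D cells (Homo sapiens) for cytotoxicity, read by CCK-8 assay and cell counting, with a stated time of 2 days; on this read-out lower numbers stand for stronger inhibition and higher numbers for weaker inhibition; its number is the largest of the three measured. Compound 2 `Oc1ccc(-c2cc(-c3ccc(Cl)cc3)nc(-c3cccs3)c2)cc1` gives 6450 nM, and a 1.6-fold lower number from compound 1 to compound 2 (0.21 log units; within the scatter). Compound 3 `Oc1cccc(-c2cc(-c3cccs3)nc(-c3ccccc3Cl)c2)c1` gives 3990 nM, and a 2.6-fold lower number from compound 1 to compound 3 (0.42 log units; beyond the scatter). Compound 4 `Oc1cccc(-c2cc(-c3ccccc3)nc(-c3ccc(Cl)cc3)c2)c1` carries phenyl in place of thiophen-2-yl on an aromatic carbon. Neither measured step touches the thiophen-2-yl group: one moves the hydroxyl, the other the chlorine, so nothing recorded here speaks directly to this exchange. The two steps seen are small, and the change in compound 4 is of comparable scale, so no step beyond the scatter is expected in this assay, with the direction open. For compound 4 the estimate is 8500 nM, expected between 3000 nM and 25000 nM, that is a 1.2-fold lower number from compound 1 to compound 4 (0.09 log units; within the scatter).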

Compound 4, half-maximal inhibitory concentration: 11300 nM
Beside the measured number, compound 4's estimate is 1.3-fold (0.12 log units) below it; low and high end bracket the measured number.
By their numbers in this assay, from the lowest: compounds 3, 2, 1 and 4 (each within the scatter of the next, the first and the last beyond it).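

In this assay, within the data shown here, the first exchange at this position, on the aromatic carbon next to the ring nitrogen, gives a 1.1-fold higher number from compound 1 to compound 4 (0.03 log units; within the scatter), so thiophen-2-yl and phenyl cannot be told apart here. With the 3-hydroxyphenyl and 4-chlorophenyl groups held fixed, this position accepts either aromatic ring without a step beyond the scatter. Nothing available accounts for this result.

On these data alone, whether the same exchange reads alike alongside the 4-hydroxyphenyl group of compound 2 or the 2-chlorophenyl group of compound 3 stays open. So does the effect of a non-aromatic group at this carbon, such as an amine or a carboxylic acid.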